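The compounds below may be only part of what the source reports. "The series", "measured", "known", "first", "only" and "open" are said of these compounds alone.

Measured so far in a physicochemical assay for solubility, measured as kinetic solubility; a lower number here means a less soluble compound, a higher number a more soluble compound:
- compound 1 `CCC/N=C1\S/C(=C\c2ccc(O)c(Br)c2)C(=O)N1c1ccccc1C` gives 79000 nM
- compound 2 `Cc1ccccc1N1C(=O)/C(=C/c2ccc(O)c(Cl)c2)S/C1=N\CCCF` gives 20000 nM

Compound 2 has the lower number of the two, and its gap to compound 1 lies beyond the usual scatter. The unmeasured compound 3 `CCC/N=C1\S/C(=C\c2ccc(O)c(Cl)c2)C(=O)N1c1ccccc1C` comes from compound 2 by one change, hydrogen in place of fluoro on a saturated chain carbon, three bonds along the chain from a double-bonded nitrogen (hydrogen in place of fluoro on a saturated chain carbon, three bonds along the chain from a double-bonded nitrogen; 3-fluoropropyl to propyl). For the measured compounds named here, no measured step isolates this change, since compound 1 and compound 2 differ in more than one place. Going by the values given here, the only higher reference is compound 1, which carries the propyl chain and gives 79000 nM in this assay, so a modest rise is expected, tentatively. The expected 2.0-fold higher number from compound 2 to compound 3 (0.30 log units; within the scatter) is upward. The estimated value for compound 3 is 40000 nM (range 14000 nM to 90000 nM).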

Compound 3, solubility: 79000 nM
The estimate for compound 3 lay 2.0-fold (0.30 log units) below the measured number; measured number inside the range.
By their numbers in this assay, from the lowest: compound 2; then compounds 1 and 3 (each within the scatter of the next).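

Working notes: in this assay the change from 3-fluoropropyl to propyl now has its own step with the chloro group held fixed, a 4.0-fold higher number from compound 2 to compound 3 (0.60 log units; beyond the scatter), so fluoro on this saturated chain carbon matters in this pair. With the propyl chain held fixed, chloro in place of bromo on an aromatic carbon gives no change at the digits printed from compound 1 to compound 3 (within the scatter), and the two halogens are not told apart in this pair. No measured evidence bears on why the chain change gives this step.

Still open, from the compounds shown here alone, is whether the fluoro step carries over to the bromo compound, since it rests on a single pair. Also open, going by these compounds, is where a 2-fluoroethyl chain, a butyl chain or a 3-aminopropyl chain would fall in this assay on the same core.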